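Notes on the ethoxy-to-chloro exchange in the series

The compounds below may be only part of what the source reports. "The series", "measured", "known", "first", "only" and "open" are said of these compounds alone.

The shared core is that of compound 2 `C=C(Br)C(=O)Nc1cccc(-c2cn3nc(-c4ccc(OCC)cc4)sc3n2)c1`. Going by the values given here, in a functional assay on CCRF-CEM cells (Homo sapiens) for inhibition, read by cell counting, with a stated time of 3 days (on this read-out lower numbers stand for stronger inhibition and higher numbers for weaker inhibition), compound 2 gives 1400 nM, the lowest number among the values measured so far. Compound 3 `COc1ccc(-c2csc3nc(-c4cccc(N)c4)cn23)cc1`, with a different arrangement of the core and no acyl group on the aromatic nitrogen, gives 6100 nM in this assay. Compound 1 `CCOc1ccc(-c2nn3cc(-c4cccc(N)c4)nc3s2)cc1` is reported in this assay only as a limit, > 250000 nM. Among the compounds with values here, the one single-place step measured, an at least 170-fold lower number from compound 1 to compound 2 (2.25 log units; beyond the scatter), concerns the aromatic nitrogen and rests on that limit (the limit of > 250000 nM in this assay, at which 1 of the 3 values shown sits).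

Compound 4 `C=C(Br)C(=O)Nc1cccc(-c2cn3nc(-c4ccc(Cl)cc4)sc3n2)c1` differs from compound 2 by chloro in place of ethoxy on an aromatic carbon. Within the data shown here, no measured step touches that position; the acylated nitrogen step says nothing about the group para to the large group. The expectation in this assay is therefore a number close to that of compound 2, with a shift in either direction not beyond the usual scatter. Compound 4 is estimated at 1500 nM, within 500 nM to 5000 nM, which corresponds to an expected step of a 1.1-fold higher number from compound 2 to compound 4 (0.03 log units; within the scatter).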

Compound 4, half-maximal inhibitory concentration: 3200 nM
For compound 4 the middle estimate is 2.1-fold (0.33 log units) below the measured one; the range from low to high includes it.
By their numbers in this assay, from the lowest: compound 2; then compounds 4 and 3 (each within the scatter of the next). At a limit, above all of these: compound 1.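

The position para to a large group on the six-membered aromatic ring does move the number in this assay: a 2.3-fold higher number from compound 2 to compound 4 (0.36 log units; beyond the scatter). Going by these compounds alone, this is the only measured step at this position, and its modest size shows that ethoxy is not needed for compound 4 to keep a number in the low micromolar range, with the acylated nitrogen left unchanged. No measurement shown bears on why chloro in place of ethoxy gives this shift.

Ethoxy and chloro differ in both heavy atoms and hydrogen-bond acceptors, so this single step cannot separate the contribution of either difference. Going by these compounds, how an amine, a carboxylic acid or a longer chain such as butoxy would read at this position, with the rest of compound 2 kept, remains open.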